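Swapping a chloro for a hydroxy on a thiosemicarbazone

This account rests on a few compounds, and the source may have more. Where it says the series, first, only, none or still open, it means among the compounds named here.

Of the compounds shown here, three sharing a cyclohexyl thiosemicarbazone core have been tested in a functional assay on MDA-MB-231 cells (Homo sapiens) for inhibition, read by WST assay, with a stated time of 48 h; a lower number here means a stronger inhibitor, a higher number a weaker inhibitor. Compound 1 `O=[N+]([O-])c1cccc(/C=N\NC(=S)NC2CCCCC2)c1` gives 84800 nM. Compound 2 `S=C(N/N=C\c1ccc(Cl)cc1)NC1CCCCC1` gives 38300 nM. Compound 3 `S=C(N/N=C\c1ccco1)NC1CCCCC1` gives 141000 nM. Compound 2 therefore holds the lowest number of the three, and its gaps to compound 1 and to compound 3 both lie beyond the usual scatter, so it is the strongest inhibitor among them in this assay.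

The next compound, compound 4 `Oc1ccc(/C=N\NC(=S)NC2CCCCC2)cc1`, is not yet measured. It differs from compound 2 in one place: hydroxy in place of chloro on an aromatic carbon. Among the measured compounds shown here, no pair of measured compounds here differs by exactly this kind of change, so there is no measured step to lean on. The three values do show that every variation of the aromatic part so far has moved the number upward from compound 2, and the expectation is that compound 4 will follow that tendency by a modest step in this assay, weaker rather than stronger. Compound 4 is expected to give roughly 65000 nM, within a range from 20000 nM to 200000 nM. This expectation corresponds to an estimated step of a 1.7-fold higher number from compound 2 to compound 4 (0.23 log units; within the scatter).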

Compound 4, half-maximal inhibitory concentration: 115000 nM
The estimate for compound 4 lay 1.8-fold (0.25 log units) below the measured number, within the range that was stated.
By their numbers in this assay, from the lowest: compound 2; then compounds 1, 4 and 3 (each within the scatter of the next).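

Among the compounds shown here, this is the first single-group change on the aromatic ring to be read directly. In this assay, hydroxy in place of chloro gives a 3.0-fold higher number from compound 2 to compound 4 (0.48 log units; beyond the scatter), so inhibition at this place, para to a large group, depends on which group sits there. The swap leaves the count at one heavy atom, yet it adds one hydrogen-bond donor and one hydrogen-bond acceptor, showing that replacing a single atom here can shift the number beyond the scatter. No measurement among these compounds tells why the number rises.

As far as these compounds go, it remains open whether other groups at this place, such as fluoro, methoxy or an amine, would keep the number of compound 2 or move it as hydroxy does. Also open, from the compounds shown here alone, is how a plain hydrogen at this place would compare with chloro and hydroxy.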